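The compounds below may be only part of what the source reports. "The series", "measured", "known", "first", "only" and "open" are said of these compounds alone.

Compounds measured so far:

Compound 1, `CCn1cc(-c2nc3ccc([N+](=O)[O-])cc3[nH]2)c(=O)c2cc(F)c(N3CCNCC3)nc21`: in a functional assay on Bel-7402 cells (Homo sapiens) for cytotoxicity, read by MTT assay, with a stated time of 48 h (on this read-out higher numbers stand for weaker inhibition and lower numbers for stronger inhibition), compound 1 gives 10800 nM.
Compound 2, `CCn1cc(-c2nc3ccc([N+](=O)[O-])cc3[nH]2)c(=O)c2cc(F)c(N3CCN(C)CC3)cc21`: in this assay compound 2 gives 4400 nM.
Compound 3, `CCn1cc(-c2nc3ccc(N)cc3[nH]2)c(=O)c2cc(F)c(N3CCN(C)CC3)cc21`: in this assay compound 3 gives > 50000 nM, which is a limit of the assay and not a number.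

Compound 3 differs from compound 2 by amino in place of nitro on an aromatic carbon. That change made an at least 11-fold higher number from compound 2 to compound 3 (1.05 log units; beyond the scatter), and the value for compound 3 sits at the limit of > 50000 nM in this assay, at which 1 of the 3 values shown sits. How the core of compound 1 differs from that of compound 2 is not broken down here; of the two, compound 1 has the higher number.

Compound 4, `CCn1cc(-c2nc3ccc(N)cc3[nH]2)c(=O)c2cc(F)c(N3CCNCC3)nc21`, is not yet measured. It differs from compound 1 by amino in place of nitro on an aromatic carbon. The place of this change is described in the same words as for the change from compound 2 to compound 3, so it is the same change made on the other core.

Among the compounds with values here, compound 4 is therefore expected to show a 10-fold higher number from compound 1 to compound 4 (1.01 log units; beyond the scatter), an expectation that rests on an at least 11-fold higher number from compound 2 to compound 3 (1.05 log units; beyond the scatter), the only example of this change so far. Since compound 1 already starts from the higher of the two measured numbers, compound 4 is expected to reach 110000 nM, most likely reported only as a limit, with a range from 30000 nM to 400000 nM.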

Compound 4, half-maximal inhibitory concentration: 93300 nM
The estimate for compound 4 lay 1.2-fold (0.07 log units) above the measured number; the range from low to high includes it.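

In this assay, amino in place of nitro on the core of compound 1 gave an 8.6-fold higher number from compound 1 to compound 4 (0.94 log units; beyond the scatter), so the weakening seen on the other core appeared here too, and on both cores the step lies beyond the scatter. Set side by side, the two examples read: the same change on two cores in this assay, an at least 11-fold higher number (1.05 log units; beyond the scatter) from compound 2 to compound 3 and an 8.6-fold higher number (0.94 log units; beyond the scatter) from compound 1 to compound 4; the limit leaves it open whether they differ. For compound 3 the reading of > 50000 nM is a limit of the assay and not a number, so the pair shows that the direction of the change carried over from one core to the other, but not that its size did.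

From the compounds shown here alone, only nitro and amino appear at this place on the aromatic ring, so it remains open how a nitrile, an acetamide or a chlorine there would read in this assay. Also open, going by these compounds, is whether the same step would hold on a third core, as these two cores are the only ones that show it.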